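Replacing a Methyl with a Bromophenyl on the Ring Amine

This account rests on a few compounds, and the source may have more. Where it says the series, first, only, none or still open, it means among the compounds named here.

Compound 3 `CCCn1c(=O)[nH]c2nc(-c3ccc(S(=O)(=O)N4CCN(C)CC4)cc3)[nH]c2c1=O` gives 48.2 nM in an assay on CHO cells for displacement of a labelled ligand from adenosine receptor A2b (Homo sapiens), read by scintillation counting, with a stated time of 75 min, in the presence of a further agent that is not named here (on this read-out lower numbers stand for stronger inhibition and higher numbers for weaker inhibition), the highest number among the three measured compounds, while compound 1 `CCCn1c(=O)[nH]c2nc(-c3ccc(S(=O)(=O)N4CCN(c5ccc(F)cc5)CC4)cc3)[nH]c2c1=O` gives 0.644 nM and compound 2 `CCCn1c(=O)[nH]c2nc(-c3ccc(S(=O)(=O)N4CCN(c5ccc(Br)cc5)CC4)cc3)[nH]c2c1=O` gives 0.0835 nM. Compound 4 `CCCn1c(=O)[nH]c2nc(-c3ccc(S(=O)(=O)N4CCN(c5ccccc5Br)CC4)cc3)[nH]c2c1=O` differs from compound 3 by 2-bromophenyl in place of methyl on an amine nitrogen in a ring. Among the measured compounds shown here, two measured steps bear on this change: a 75-fold higher number from compound 1 to compound 3 (1.87 log units; beyond the scatter) and a 580-fold higher number from compound 2 to compound 3 (2.76 log units; beyond the scatter), both large, so going the other way is expected to bring a large fall in the number. The entering group is 2-bromophenyl rather than the 4-bromophenyl of compound 2, so the exact size is uncertain. Compound 4 is expected to give about 1 nM, within 0.1 nM to 10 nM. This means an expected step of a 48-fold lower number from compound 3 to compound 4 (1.68 log units; beyond the scatter).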

Compound 4, inhibition constant: 0.137 nM
Beside the measured number, compound 4's estimate is 7.3-fold (0.86 log units) above it; low and high end bracket the measured number.
By their numbers in this assay, from the lowest: compounds 2 and 4 (each within the scatter of the next); then compound 1; then compound 3.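

In this assay, 2-bromophenyl on the ring nitrogen keeps the large gain over methyl (a 350-fold lower number from compound 3 to compound 4 (2.55 log units; beyond the scatter)), so that gain does not depend on the 4-bromophenyl arrangement of compound 2. The two bromophenyl compounds cannot be told apart (a 1.6-fold higher number from compound 2 to compound 4 (0.22 log units; within the scatter)), and the 2-bromophenyl group also gives a modest gain over 4-fluorophenyl (a 4.7-fold lower number from compound 1 to compound 4 (0.67 log units; beyond the scatter)). No evidence here explains these steps. On these data alone, whether an unsubstituted phenyl or a benzyl group on this nitrogen would also give such low numbers stays open.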